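This account rests on a few compounds, and the source may have more. Where it says the series, first, only, none or still open, it means among the compounds named here.

For the measured compounds named here, in a functional assay on A2780 cells (Homo sapiens) for cytotoxicity, read by sulforhodamine B assay, with a stated time of 72 h (on this read-out higher numbers stand for weaker inhibition and lower numbers for stronger inhibition), two compounds sharing one core have numbers so far. Compound 1 `CC(C)n1cc(S(=O)(=O)c2ccc(CNC(=O)N3Cc4ccncc4C3)cc2)cn1` gives 11 nM, and compound 2 `O=C(NCc1ccc(S(=O)(=O)C2CCN(C3COC3)CC2)cc1)N1Cc2ccncc2C1` gives 7.4 nM. These values lie within the usual scatter of each other, so compound 2 stands level with compound 1. Compound 3 `CN1CCC(S(=O)(=O)c2ccc(CNC(=O)N3Cc4ccncc4C3)cc2)CC1` differs from compound 2 in one place, with methyl in place of oxetan-3-yl on an amine nitrogen in a ring. Going by the values given here, the only measured step, a 1.5-fold lower number from compound 1 to compound 2 (0.17 log units; within the scatter), exchanged the whole group on the sulfonyl sulfur and stayed within the scatter. It does not test this amine nitrogen alone, so it offers only indirect guidance. No step beyond the scatter is therefore expected in this assay, and neither direction is favoured. The expected step is a 1.4-fold higher number from compound 2 to compound 3 (0.13 log units; within the scatter). For compound 3, the estimated value is 10 nM, with an expected range from 4 nM to 25 nM.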

Compound 3, half-maximal inhibitory concentration: 99 nM
Compound 3: middle estimate off by 9.9-fold (1.00 log units), on the low side; measured number above the stated range.
By their numbers in this assay, from the lowest: compounds 2 and 1 (each within the scatter of the next); then compound 3.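

In this assay the group on the amine nitrogen in a ring proves to matter: methyl in place of oxetan-3-yl gives a 13-fold higher number from compound 2 to compound 3 (1.13 log units; beyond the scatter), a step beyond the scatter, whereas the earlier exchange on the sulfonyl sulfur stayed within it. Against the 1-isopropyl-1H-pyrazol-4-yl group, 1-methylpiperidin-4-yl also gives a 9.0-fold higher number from compound 1 to compound 3 (0.95 log units; beyond the scatter), so 1-(oxetan-3-yl)piperidin-4-yl stands level with the pyrazole group, while 1-methylpiperidin-4-yl does not. Nothing available explains this difference.

The compounds shown leave open whether the four-membered ring, its oxygen or simply the size of the group accounts for the step. A cyclobutyl group on the same nitrogen would keep the ring without the oxygen, and a 2-methoxyethyl chain would keep an oxygen without the ring.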